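Amide Replacement on a Proline-Linked Aminopyrimidine Series

The source may report more compounds than this note shows. Statements on the series, on what has been measured and on what is new or still open speak of the compounds shown alone.

Compound 1 `CN(CCCn1ccnc1)C(=O)[C@@H]1CCCN1c1nccc(Nc2ccccc2)n1` was examined in an assay on isolated protein for inhibition of vascular endothelial growth factor receptor 1 (Homo sapiens), read by HTRF, tested at 10 uM (a higher number here means more inhibition at the concentration tested (going by the name of the read-out), a lower number less inhibition), where compound 1 gives 4%. Among the three measured compounds it sits alongside compound 2 `Cc1cccc(Oc2ccnc(N3CCN(C(=O)c4c(C)noc4C)CC3)n2)c1`, which in this assay gives 7%, and compound 3 `Cc1cccc(Nc2ncnc3c2CN(C(=O)c2ccc(N(C)C)c4ccccc24)CC3)c1`, which gives 1%; the gap from compound 1 to each of the other two lies within the usual scatter, so the three cannot be told apart. Compound 4 `CN(C)CC(C)(C)CNC(=O)[C@@H]1CCCN1c1nccc(Nc2ccccc2)n1` differs from compound 1 in one place: (2-((dimethylamino)methyl)-2-methylpropyl)amino in place of (3-(1H-imidazol-1-yl)propyl)(methyl)amino on a carbonyl carbon. Among the compounds with values here, no measured pair shows a comparable change, so no step beyond the scatter is expected in this assay from compound 1 to compound 4. Compound 4 is therefore estimated at 5% in this assay, with a range from -5% to 15%, an expected step of a number 1 percentage points higher from compound 1 to compound 4 (within the scatter).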

Compound 4, a percentage reported as inhibition, at one concentration (the size of the read-out at that concentration, not a potency): 12%
Estimate against measurement, compound 4: 7 percentage points below; measured number inside the range.
By their numbers in this assay, from the lowest: compounds 3, 1, 2 and 4 (each within the scatter of the next, the first and the last beyond it).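

In this assay the exchange on this carbonyl carbon gives a number 8 percentage points higher from compound 1 to compound 4 (within the scatter) and so shows that the five-membered aromatic ring of the leaving group can give way to an open chain with an amide hydrogen without a step beyond the scatter. Nothing presented here explains this result. Going by these compounds, whether a morpholine, a carboxylic acid or a longer chain on the same carbonyl carbon would produce a step beyond the scatter remains open.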